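Adding fluorine beside the trifluoromethyl group: a small step

The compounds below may be only part of what the source reports. "The series", "measured", "known", "first", "only" and "open" are said of these compounds alone.

Measured so far:
- compound 1, `CCc1nc(Cl)c2n1CCN([C@@H](C(=O)NC)c1ccccc1)[C@H]2CCc1cccc(C(F)(F)F)c1`: 72 nM
- compound 2, `CCc1nc(Cl)c2n1CCN([C@@H](C(=O)NC)c1ccccc1)[C@H]2CCc1ccc(C(F)(F)F)c(Cl)c1`: 20 nM

In a functional assay on CHO cells for antagonist activity at Orexin/Hypocretin receptor type 1 (Homo sapiens), read by FLIPR and calcium flux (on this read-out lower numbers stand for stronger inhibition and higher numbers for weaker inhibition), compound 1 gives 72 nM, the highest of the two numbers; its nearest neighbour, compound 2, gives 20 nM. For the measured compounds named here, the one measured step, a 3.6-fold lower number from compound 1 to compound 2 (0.56 log units; beyond the scatter), swaps in a different halogen at a different place, so it only loosely bears on compound 3, `CCc1nc(Cl)c2n1CCN([C@@H](C(=O)NC)c1ccccc1)[C@H]2CCc1cccc(C(F)(F)F)c1F`. Compound 3 differs from compound 1 by fluoro in place of hydrogen on an aromatic carbon. Going by the values given here, with no directly matching step, a change of a size near the scatter is expected, leaning toward a lower number: a 1.4-fold lower number from compound 1 to compound 3 (0.16 log units; within the scatter). Compound 3 is therefore estimated at 50 nM, within 20 nM to 150 nM.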

Compound 3, half-maximal inhibitory concentration: 16 nM
Compound 3: middle estimate off by 3.1-fold (0.49 log units), on the high side; measured number outside the range, below it.
By their numbers in this assay, from the lowest: compounds 3 and 2 (each within the scatter of the next); then compound 1.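

A single fluoro on an aromatic carbon, ortho to a trifluoromethyl group, makes a clear difference here, giving a 4.5-fold lower number from compound 1 to compound 3 (0.65 log units; beyond the scatter) and a stronger inhibitor than compound 1. The 2-fluoro-3-(trifluoromethyl)phenyl and 3-chloro-4-(trifluoromethyl)phenyl groups cannot be told apart, with a 1.3-fold lower number from compound 2 to compound 3 (0.10 log units; within the scatter) and no ranking of the two possible. No measurement here accounts for the effect of the fluoro.

As far as these compounds go, whether a chloro or a methyl group on that same aromatic carbon would do the same remains open. So does the effect of a fluoro on the other carbons of this ring.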